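Adding One Methoxy to Compound 3: What to Expect

This account rests on a few compounds, and the source may have more. Where it says the series, first, only, none or still open, it means among the compounds named here.

Measured compounds in an assay for antagonist activity at proteinase-activated receptor 4 (Homo sapiens), with stated times of 5 min, 50 s and 15 min, in the presence of a further agent that is not named here; on this read-out lower numbers stand for stronger inhibition and higher numbers for weaker inhibition:
Compound 3 `COc1nn2cc(-c3cc4ccccc4o3)nc2s1` — compound 3 gives 240 nM
Compound 1 `COc1nn2cc(-c3cc4ccc(OCc5ccccc5)cc4o3)nc2s1` — compound 1 gives 1800 nM
Compound 2 `COc1nn2cc(-c3cc4c(OC)ccc(OC)c4o3)nc2s1` — compound 2 gives 2100 nM

Compound 3 holds the lowest number of the three in this assay. Its nearest neighbour is compound 1, and the step of a 7.5-fold lower number from compound 1 to compound 3 (0.88 log units; beyond the scatter) shows that removing the benzyloxy from the shared core brought the number down by a margin beyond the scatter. Compound 2, carrying two methoxy groups on the same core, sits even further from compound 3, though no single-point comparison links those two.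

Compound 4 `COc1nn2cc(-c3cc4cccc(OC)c4o3)nc2s1` has not yet been measured. It differs from compound 3 by methoxy in place of hydrogen on an aromatic carbon. Within the data shown here, the only single-point step on record, a 7.5-fold lower number from compound 1 to compound 3 (0.88 log units; beyond the scatter), concerns a different group at a different place, so it bears on this change only loosely; the values of compound 2 and compound 3 add that a methoxy-bearing core has so far scored higher than the bare one. On that basis a modest rise in the number for compound 4 is expected, a 2.5-fold higher number from compound 3 to compound 4 (0.40 log units; beyond the scatter). Compound 4 is therefore estimated at 600 nM, within a range of 200 nM to 2500 nM.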

Compound 4, half-maximal inhibitory concentration: 240 nM
The estimate for compound 4 lay 2.5-fold (0.40 log units) above the measured number; measured number inside the range.
By their numbers in this assay, from the lowest: compounds 3 and 4 (each within the scatter of the next); then compounds 1 and 2 (each within the scatter of the next).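

In this assay the methoxy of compound 4, on an aromatic carbon of the six-membered ring, ortho to a fused ring and meta to a fused ring, leaves the number where it was (no change at the digits printed from compound 3 to compound 4 (within the scatter)). Among these compounds, this position therefore takes a methoxy without a change beyond the scatter, something the earlier compounds could not show, since compound 2 carries two methoxy groups and its number alone cannot separate them. The second step (an 8.8-fold lower number from compound 2 to compound 4 (0.94 log units; beyond the scatter)) keeps this methoxy and takes away the other one, so the high number of compound 2 goes with that other methoxy, or with the two together, and not with the methoxy at this position alone.

No measurement offered here accounts for this difference between the two methoxy groups.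

The compounds shown leave open whether this carbon would take something larger or of another kind, such as an ethoxy, a benzyloxy, an amine or a carboxylic acid, as it takes methoxy. They also leave open whether the other methoxy of compound 2 would raise the number when it stands alone on the shared core.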